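This account rests on a few compounds, and the source may have more. Where it says the series, first, only, none or still open, it means among the compounds named here.

Working notes on the series.

Compound 3 `O=C(O)c1cc(-c2c[nH]cn2)ccc1O` is, in a functional assay on the whole organism for inhibition, with Rattus norvegicus as the target, read by paw edema (on this read-out lower numbers stand for an effect already at smaller amounts and higher numbers for an effect only at larger amounts of compound), the higher of the two numbers in hand: compound 3 gives 100 mg/kg. Its nearest neighbour is compound 2 `O=C(O)c1cc(-n2cccc2)ccc1O`, which in this assay gives 50 mg/kg; the step of a 2.0-fold higher number from compound 2 to compound 3 (0.30 log units; within the scatter) lies within the scatter, so the two compounds are not separated. Compound 1 `O=C(O)c1cc(-c2cncs2)ccc1O` returns only a limit of the assay in this assay, > 200 mg/kg, as recorded in the limit of > 200 mg/kg in this assay, at which 1 of the 3 values shown sits.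

The step to compound 4 `O=C(O)c1cc(C2N=NN=N2)ccc1O` is a group of 5 heavy atoms (1 carbon, 4 nitrogen; one five-membered non-aromatic ring with 4 hetero atoms) in place of a group of 5 heavy atoms (3 carbon, 2 nitrogen; one five-membered aromatic ring with 2 hetero atoms), on an aromatic carbon.

For the measured compounds named here, three measured steps bear on this position, all exchanges of the five-membered ring on the same aromatic carbon: an at least 4.0-fold lower number from compound 1 to compound 2 (0.60 log units; beyond the scatter), an at least 2.0-fold lower number from compound 1 to compound 3 (0.30 log units; that floor lies within the scatter) and a 2.0-fold higher number from compound 2 to compound 3 (0.30 log units; within the scatter). As far as these compounds go, of these, only the first is clearly beyond the scatter, and it runs from a limit, so its true size is unknown. The two numbered compounds sit within the scatter of each other. Exchanges of the ring at this position have therefore produced at most modest movement among the compounds measured, and no direction for a further ring exchange can be read from them.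

The step of no change at the digits printed from compound 3 to compound 4 (within the scatter) is expected to stay within the scatter. Compound 4 is therefore estimated at 100 mg/kg, with a range from 40 mg/kg to 250 mg/kg.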

Compound 4, dose for half-maximal effect in the Rattus norvegicus assay: 110 mg/kg
The estimate for compound 4 lay 1.1-fold (0.04 log units) below the measured number, and the stated range covers the measured number.
By their numbers in the Rattus norvegicus assay, from the lowest: compounds 2, 3 and 4 (each within the scatter of the next, the first and the last beyond it). At a limit, above all of these: compound 1.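

In the Rattus norvegicus assay compound 3 gives 100 mg/kg and compound 4 gives 110 mg/kg. In the Rattus norvegicus assay, a ring with 0 hydrogen-bond donors and 4 hydrogen-bond acceptors on this aromatic carbon is not separated from the 1H-imidazol-4-yl group, with 1 hydrogen-bond donor and 1 hydrogen-bond acceptor: a 1.1-fold higher number from compound 3 to compound 4 (0.04 log units; within the scatter). The 1H-pyrrol-1-yl group now has a modest separation from the entering ring, a 2.2-fold higher number from compound 2 to compound 4 (0.34 log units; beyond the scatter), although compound 3 lies within the scatter of both compound 2 and compound 4, so this is a small gap at the ends of a closely spaced set and not a clear trend. In a physicochemical assay for solubility, in phosphate buffer, at pH 7 (a lower number here means a less soluble compound, a higher number a more soluble compound), compound 3 gives 1100 ug/mL and compound 4 gives 1700 ug/mL. In the physicochemical assay, the same exchange also stays within the scatter: a 1.5-fold higher number from compound 3 to compound 4 (0.19 log units; within the scatter).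

Compound 1 carries a limit of the assay: the limit of > 200 mg/kg in the Rattus norvegicus assay, at which 1 of the 4 values shown sits. In the Rattus norvegicus assay its step to compound 4 gives only a floor, and that floor lies within the scatter, so the step cannot be read as a separation: an at least 1.8-fold lower number from compound 1 to compound 4 (0.25 log units; that floor lies within the scatter). The compounds shown leave open how an amine, an amide or a longer chain on this aromatic carbon would read in the Rattus norvegicus assay, and whether any group at this position can bring a change larger than the modest one seen so far among the numbered compounds.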